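This account rests on a few compounds, and the source may have more. Where it says the series, first, only, none or still open, it means among the compounds named here.

Working notes on the series.

The shared core of compound 3 `CS(=O)(=O)c1cc(C(=O)N=C(N)N)ccc1-n1ccnc1` carries a 1H-imidazol-1-yl group; in a functional assay for inhibition of sodium/hydrogen exchanger (Oryctolagus cuniculus) (a higher number here means a weaker inhibitor, a lower number a stronger inhibitor), compound 3 gives 150 nM, the highest of the three numbers recorded. Compound 1 `Cc1ccc(-c2ccc(C(=O)N=C(N)N)cc2S(C)(=O)=O)cc1` bears 4-methylphenyl at the same position and in this assay compound 1 gives 100 nM; the step from compound 1 to compound 3 is a 1.5-fold higher number from compound 1 to compound 3 (0.18 log units; within the scatter). Within the data shown here, compound 2 `Cc1cc(-n2ccnc2)c(S(C)(=O)=O)cc1C(=O)N=C(N)N` differs from compound 3 by a methyl on an aromatic carbon and in this assay compound 2 gives 23 nM; the step from compound 2 to compound 3 is a 6.5-fold higher number from compound 2 to compound 3 (0.81 log units; beyond the scatter), so the methyl is the one change here that moves the number beyond the scatter.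

Compound 4 `CS(=O)(=O)c1cc(C(=O)N=C(N)N)ccc1C1CCCCC1` is not yet measured. The change from compound 3 is cyclohexyl in place of 1H-imidazol-1-yl on an aromatic carbon. Among the measured compounds shown here, the only measured step that bears on this position is the one from compound 1 to compound 3, which stayed within the scatter when an aromatic carbocycle gave way to the imidazolyl; no measured pair shows a non-aromatic ring of carbon only at this place. The expectation for compound 4 in this assay is therefore a step of about a 1.3-fold lower number from compound 3 to compound 4 (0.10 log units; within the scatter), not clearly beyond the scatter in either direction. The estimate for compound 4 in this assay is 120 nM, with a range from 40 nM to 400 nM.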

Compound 4, half-maximal inhibitory concentration: 340 nM
Compound 4: middle estimate off by 2.8-fold (0.45 log units), on the low side; low and high end bracket the measured number.
By their numbers in this assay, from the lowest: compound 2; then compounds 1 and 3 (each within the scatter of the next); then compound 4.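

In this assay this position proves sensitive to the ring it carries: cyclohexyl in place of 1H-imidazol-1-yl gives a 2.3-fold higher number from compound 3 to compound 4 (0.36 log units; beyond the scatter), and cyclohexyl in place of 4-methylphenyl gives a 3.4-fold higher number from compound 1 to compound 4 (0.53 log units; beyond the scatter), both modest, whereas the exchange between the two aromatic groups stayed within the scatter. Among the three groups seen here, 1H-imidazol-1-yl and 4-methylphenyl cannot be told apart, and the six-membered non-aromatic ring of carbon only is the one that separates from both, a reading that rests on these three compounds alone. No measurement at hand accounts for this separation.

With a single non-aromatic ring in the set, the compounds shown cannot say whether the shift belongs to non-aromatic rings in general or to cyclohexyl itself, and a piperidin-1-yl ring or an open n-butyl chain at this place would bear on that question. Also open, as far as these compounds go, is whether the methyl on an aromatic carbon that separates compound 2 from compound 3 would give a similar step when cyclohexyl is present.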